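The source may report more compounds than this note shows. Statements on the series, on what has been measured and on what is new or still open speak of the compounds shown alone.

Two compounds of this series have so far been run in a functional assay on the whole organism (artery, strain albino) with Rattus norvegicus as the target, with a stated time of 720 min, at a dose of 10 mg/kg by the oral route; on this read-out higher numbers stand for more inhibition at the one dose given (going by the name of the read-out) and lower numbers for less inhibition. Compound 1 `COc1ccc(C2N=C(SCc3ccccc3)NC(C)=C2C(=O)Nc2ccc(F)cc2)cc1OC` gives 1.5%, and compound 2 `CC1=C(C(=O)Nc2ccc(Br)cc2)C(c2ccc(Cl)cc2Cl)N=C(SCc2ccccc2)N1` gives 11.3%; the two numbers lie within the scatter of each other, so neither is set apart. Compound 3 `CC1=C(C(=O)Nc2ccc(Br)cc2)C(c2ccc(Cl)cc2Cl)N=C(SCc2ccc(F)cc2)N1` has not yet been measured. It differs from compound 2 in one place: fluoro in place of hydrogen on an aromatic carbon. Among the measured compounds shown here, no measured pair carries the same difference, so no step in this assay is known for it; a change of no size beyond the scatter is expected, in either direction. Compound 3 is expected at 12%, between 2% and 25%. The step this expectation means is a number 0.7 percentage points higher from compound 2 to compound 3 (within the scatter).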

Compound 3, a percentage reported as inhibition, in the whole organism at one dose (the size of the read-out at that dose, not a potency): 27.3%
Beside the measured number, compound 3's estimate is 15.3 percentage points below it; the measured number lies above the stated range.
By their numbers in this assay, from the lowest: compounds 1 and 2 (each within the scatter of the next); then compound 3.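

Among the compounds shown here, the change from benzylsulfanyl to (4-fluorobenzyl)sulfanyl gives a number 16 percentage points higher from compound 2 to compound 3 (beyond the scatter) in this assay and is the first step to stand clear of the scatter, so this aromatic ring responds to a single fluoro in place of hydrogen. The finding rests on one pair at one dose. No measurement at hand accounts for the step.

Going by these compounds, whether an amine or a carboxylic acid at the same place would extend this step or reverse it remains open. Also open, on these data alone, is whether the same fluoro gives a similar step on the core of compound 1.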